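The source may hold more compounds than are shown below. What is called first, only, known or untested is meant among the compounds shown, and "the series" means these compounds.

Compound 1: `CCn1c(C(=O)N(C)c2ccccc2)ccc1C(CC)(CC)c1ccc(OCC(O)C(C)(C)C)c(C)c1` with 6400 nM in an assay on HL-60 cells for agonist activity at vitamin D3 receptor (Homo sapiens), read by microscopy, with a stated time of 96 h; a lower number here means that less compound is needed, a higher number that more compound is needed for the effect. Compound 2: `CC[C@@H](C)[C@H](NC(=O)c1ccc(C(CC)(CC)c2ccc(OCC(=O)C(C)(C)C)c(C)c2)n1CC)C(=O)O` with 10 nM in this assay.

Only these two compounds have been measured, and they differ in more than one place, so no single change can be credited with the gap between them. Compound 2 gives the lower of the two numbers; compound 1 needs far more compound for the same effect, and that gap is well beyond the scatter of the method.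

Compound 3 is `CC[C@@H](C)[C@H](NC(=O)c1ccc(C(CC)(CC)c2ccc(OCC(O)C(C)(C)C)c(C)c2)n1CC)C(=O)O`. It keeps the whole of compound 2 except for one change: 1-hydroxy-2,2-dimethylpropyl in place of (tert-butyl)carbonyl on a saturated chain carbon bound to an oxygen on an aromatic ring. The carbonyl group in the side chain becomes a hydroxyl-bearing carbon, with the rest of the chain unchanged. Compound 1 also carries the hydroxyl form of this chain. Its amide part differs as well, so it cannot serve as a clean guide for the size of this step.

Without a measured pair for this change, the expectation is that the step from compound 2 to compound 3 stays small, close to no change beyond the scatter, as a 1.3-fold lower number from compound 2 to compound 3 (0.10 log units; within the scatter). Compound 3 is therefore estimated to give 8 nM in this assay, with a range from 2 nM to 40 nM.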

Compound 3, half-maximal effective concentration: 2.3 nM
The estimate for compound 3 lay 3.5-fold (0.54 log units) above the measured number; low and high end bracket the measured number.
By their numbers in this assay, from the lowest: compound 3; then compound 2; then compound 1.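

In this assay, the side chain now has a comparison that changes only one place: 1-hydroxy-2,2-dimethylpropyl in place of (tert-butyl)carbonyl, on a saturated chain carbon bound to an oxygen on an aromatic ring, gives a 4.3-fold lower number from compound 2 to compound 3 (0.64 log units; beyond the scatter), so the hydroxyl form of this chain needs less compound than the carbonyl form when the rest of the molecule is that of compound 2. With the hydroxyl chain held constant, (1-carboxy-2-methylbutyl)amino in place of methyl(phenyl)amino on a carbonyl carbon gives a 2800-fold lower number from compound 1 to compound 3 (3.44 log units; beyond the scatter), a far larger step, which shows that the amide part weighs much more heavily in this assay than the change from carbonyl to hydroxyl. No measurement shown here explains why either step occurs.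

From the compounds shown here alone, it remains open whether an amine in place of the hydroxyl, or a longer chain in place of the tert-butyl end, would hold or lower the number reached by compound 3. Going by these compounds, it is equally open whether the carboxylic acid itself matters, a question that a methyl ester or a primary amide at that spot would address.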